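Adding a Hydroxymethyl Group to Compound 1

The compounds below may be only part of what the source reports. "The series", "measured", "known", "first", "only" and "open" are said of these compounds alone.

Measured so far in a functional assay on the whole organism (stomach) for inhibition, with Canis familiaris (Canis lupus familiaris) as the target, at a dose of 2 mg/kg by the intravenous route; a higher number here means a stronger effect of the compound at the dose given, a lower number a weaker effect:
compound 1 `Cc1cn2cccc(OCc3ccccc3)c2n1`, 61%
compound 2 `Cc1nc2c(COc3ccccc3)cccn2c1C`, 44%
compound 3 `Cc1nc2c(C[S+]([O-])c3ccccc3)cccn2c1C`, 0%

Compound 1 stands highest of the three numbers in this assay. Compound 2 comes nearest, yet its value lies beyond the usual scatter below compound 1, and compound 3 lies furthest away, showing no inhibition at all.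

Compound 4 `Cc1nc2c(OCc3ccccc3)cccn2c1CO` differs from compound 1 in one place: hydroxymethyl in place of hydrogen on an aromatic carbon. For the measured compounds named here, no pair of measured compounds shows this change, so there is no measured step to lean on. The expected change is a number 9 percentage points lower from compound 1 to compound 4 (within the scatter), a small downward move or none beyond the scatter. For compound 4 the estimate is 52%, with a range from 30% to 72%.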

Compound 4, a percentage reported as inhibition, in the whole organism at one dose (the size of the read-out at that dose, not a potency): 80%
Beside the measured number, compound 4's estimate is 28 percentage points below it, and the stated range ends below it.
By their numbers in this assay, from the lowest: compound 3; then compound 2; then compound 1; then compound 4.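

In this assay, the aromatic carbon next to the ring nitrogen can carry more than a hydrogen atom: hydroxymethyl there gives a number 19 percentage points higher from compound 1 to compound 4 (beyond the scatter) and so raises the effect at this dose. For the compounds shown here, this is the first measured step at this position, and it points upward, beyond the usual scatter. Nothing available gives a reason for the rise.

From the compounds shown here alone, whether the oxygen of hydroxymethyl is needed stays open, since a plain ethyl group, an aminomethyl group or a carboxylic acid on this carbon would each test that. A single step also cannot show how far a longer chain would carry the effect.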